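The source may hold more compounds than are shown below. What is called first, only, known or untested is meant among the compounds shown, and "the series" means these compounds.

Measured compounds:
compound 1, `Clc1ccc(-c2cc(-c3ccco3)nc(-c3cccs3)c2)o1` — 21800 nM
compound 2, `Clc1cccc(-c2cc(-c3ccc(Cl)o3)cc(-c3cccs3)n2)c1` — 18100 nM

Among the measured compounds shown here, in a functional assay on DU-145 cells (Homo sapiens) for cytotoxicity, in the presence of a further agent that is not named here (on this read-out higher numbers stand for weaker inhibition and lower numbers for stronger inhibition), compound 2 gives 18100 nM, and compound 1 gives 21800 nM; the two numbers lie within the scatter of each other, the only measured step being a 1.2-fold lower number from compound 1 to compound 2 (0.08 log units; within the scatter). Compound 3, `Cc1ccc(-c2cc(-c3ccc(Cl)o3)cc(-c3cccs3)n2)cc1`, is not yet measured. It differs from compound 2 in one place: 4-methylphenyl in place of 3-chlorophenyl on an aromatic carbon. For the measured compounds named here, the single measured step, a 1.2-fold lower number from compound 1 to compound 2 (0.08 log units; within the scatter), concerns the same position, exchanging one aromatic group for another there, and it stayed within the scatter. Going by the values given here, no measured step exchanges 3-chlorophenyl for 4-methylphenyl, so the expectation rests only on that one step. From it, the step from compound 2 to compound 3 in this assay is expected to be small, a 1.1-fold higher number from compound 2 to compound 3 (0.04 log units; within the scatter), with no clear direction beyond the scatter. Compound 3 is therefore estimated at 20000 nM, within a range from 8000 nM to 50000 nM.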

Compound 3, half-maximal inhibitory concentration: 19300 nM
For compound 3 the middle estimate is 1.0-fold (0.02 log units) above the measured one; the measured number falls inside the stated range.
By their numbers in this assay, from the lowest: compounds 2, 3 and 1 (each within the scatter of the next).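

In this assay, the aromatic carbon next to the ring nitrogen now carries a third aromatic group, and exchanging a chlorine-bearing phenyl for a methyl-bearing one stays within the scatter (a 1.1-fold higher number from compound 2 to compound 3 (0.03 log units; within the scatter)). Among the compounds shown here, the exchange of the furan-2-yl group for 4-methylphenyl also stays within the scatter (a 1.1-fold lower number from compound 1 to compound 3 (0.05 log units; within the scatter)), so the earlier step is no longer the only evidence that one aromatic group can replace another here without a clear shift. No supporting evidence is available to explain this result.

The compounds shown leave open whether an amine or a carboxylic acid on this carbon would move the number beyond the scatter. They also leave open what the 5-chlorofuran-2-yl and thiophen-2-yl groups contribute, since both stay the same in all three compounds.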